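The source may report more compounds than this note shows. Statements on the series, on what has been measured and on what is new or still open speak of the compounds shown alone.

Of the compounds shown here, two that share one core have been measured in a functional assay on the whole organism (strain Albino) with Mus musculus as the target, with a stated time of 0.5 h; on this read-out higher numbers stand for an effect only at larger amounts of compound and lower numbers for an effect already at smaller amounts. Compound 1 `COc1ccc(-c2cc(-c3ccc(F)cc3)nc(NC(=O)N/N=C\c3cccc(Cl)c3)n2)cc1OC` gives 300 mg/kg. Compound 2 `COc1ccc(-c2cc(-c3ccc(Cl)cc3)nc(NC(=O)N/N=C\c3ccc([N+](=O)[O-])cc3)n2)cc1OC` gives 30 mg/kg, the lowest of the two numbers, with compound 1 a higher number beyond the scatter. Compound 3 `COc1ccc(-c2cc(-c3ccc(Cl)cc3)nc(NC(=O)N/N=C\c3cccc(Cl)c3)n2)cc1OC` is not yet measured; it differs from compound 2 by 3-chlorophenyl in place of 4-nitrophenyl on a carbon with a double bond to nitrogen. For the measured compounds named here, no measured pair isolates this change. Because compound 1, which carries the same 3-chlorophenyl, gives 300 mg/kg, compound 3 is expected to shift toward it, a step of a 5.0-fold higher number from compound 2 to compound 3 (0.70 log units; beyond the scatter) in this assay. Compound 3 is thus estimated at 150 mg/kg, with a range of 50 mg/kg to 400 mg/kg.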

Compound 3, dose for half-maximal effect: 100 mg/kg
Beside the measured number, compound 3's estimate is 1.5-fold (0.18 log units) above it; the measured number falls inside the stated range.
By their numbers in this assay, from the lowest: compound 2; then compound 3; then compound 1.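

Replacing 4-nitrophenyl with 3-chlorophenyl on a carbon with a double bond to nitrogen gives a 3.3-fold higher number from compound 2 to compound 3 (0.52 log units; beyond the scatter) in this assay and thus shows, as a single change, that the group at this position alters the dose needed. Chloro in place of fluoro on an aromatic carbon gives a 3.0-fold lower number from compound 1 to compound 3 (0.48 log units; beyond the scatter) and shows that a change elsewhere on the shared core also moves the number by a step of similar size.

On these data alone, how an aminophenyl or a carboxyphenyl group at the first position would compare remains open. Nothing available explains either step.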